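Series notes: 1-benzofuran-2-yl against phenyl on the core

The compounds below may be only part of what the source reports. "The series", "measured", "known", "first", "only" and "open" are said of these compounds alone.

Compound 1 `COc1ncnc2c1c(-c1ccccc1)cn2[C@@H]1O[C@H](CO)[C@@H](O)[C@H]1O`: in a functional assay on HeLa S3 cells (Homo sapiens) for antiproliferative activity, read by XTT assay, with a stated time of 72 h (a lower number here means a stronger inhibitor, a higher number a weaker inhibitor), compound 1 reaches only the assay limit, > 20000 nM.
Compound 2 `O=c1[nH]cnc2c1c(-c1cc3ccccc3o1)cn2[C@@H]1O[C@H](CO)[C@@H](O)[C@H]1O`: in this assay compound 2 likewise reaches only the assay limit, > 20000 nM.
Compound 3 `COc1ncnc2c1c(-c1cc3ccccc3o1)cn2[C@@H]1O[C@H](CO)[C@@H](O)[C@H]1O`: in this assay compound 3 gives 9240 nM.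

Compound 2 and compound 3 carry the same 1-benzofuran-2-yl group on different cores; the difference between the two cores is not broken down here. Among the compounds with values here, compound 3 is the only number in the set. Compound 2 stands at the limit (the limit of > 20000 nM in this assay, at which 2 of the 3 values shown sit).

Within the data shown here, the one measured change is phenyl in place of 1-benzofuran-2-yl on an aromatic carbon, which gives an at least 2.1-fold higher number from compound 3 to compound 1 (0.33 log units; beyond the scatter). The same change leads from compound 2 to compound 4 `O=c1[nH]cnc2c1c(-c1ccccc1)cn2[C@@H]1O[C@H](CO)[C@@H](O)[C@H]1O`: phenyl in place of 1-benzofuran-2-yl on an aromatic carbon. The measured step ran toward weaker inhibition, and compound 2 already sits at the limit, so compound 4 is expected to sit at or beyond that limit as well. The expected step is a step that the limit leaves unreadable from compound 2 to compound 4, resting on the step of an at least 2.1-fold higher number from compound 3 to compound 1 (0.33 log units; beyond the scatter). Compound 4 is therefore estimated at 40000 nM in this assay, expected between 15000 nM and 200000 nM, most likely reported as a limit only.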

Compound 4, half-maximal inhibitory concentration: > 20000 nM
Compound 4 was reported as a limit (the forecaster's own chance of this, stated with the estimate: 90%); the middle value lies beyond the limit too.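

Compound 2 and compound 4 both stand only at a limit in this assay, so the change from 1-benzofuran-2-yl to phenyl between them gives no readable step: the limit of > 20000 nM in this assay, at which 3 of the 4 values shown sit.

The compounds shown leave open whether the step seen on the core of compound 3 also holds on the core of compound 2.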